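Adding a methoxy group to compound 2

The compounds below may be only part of what the source reports. "The series", "measured", "known", "first", "only" and "open" are said of these compounds alone.

Two compounds, compound 1 `COc1ccc(-c2nc3sc(-c4ccccc4)cn3n2)cc1` and compound 2 `Clc1ccc(-c2cn3nc(-c4ccccc4)nc3s2)cc1`, have been measured so far. In a functional assay on ACHN cells (Homo sapiens) for inhibition, read by sulforhodamine B assay, with a stated time of 48 h, tested at 10 uM (a higher number here means more inhibition of growth at the concentration tested, a lower number less inhibition of growth), compound 1 gives 32%, while compound 2 gives 49%, the higher of the two numbers and beyond the usual scatter. Compound 3 `COc1ccc(-c2nc3sc(-c4ccc(Cl)cc4)cn3n2)cc1` differs from compound 2 by one change: methoxy in place of hydrogen on an aromatic carbon. Compound 1 also carries a methoxy group and stands at 32%, so a modest fall is expected. In this assay the estimated move is a number 7 percentage points lower from compound 2 to compound 3 (within the scatter), which may stay within the scatter. For compound 3 the expected value is 42%, within a range from 25% to 58%.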

Compound 3, percent growth inhibition at one concentration: -74%
Compound 3: the middle estimate sits 116 percentage points above what was measured, and the stated range ends above it.
By their numbers in this assay, from the lowest: compound 3; then compound 1; then compound 2.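

In this assay, methoxy on this aromatic carbon, para to a large group, is far from a harmless addition when chloro is also present: the step is a number 123 percentage points lower from compound 2 to compound 3 (beyond the scatter). Adding chloro to the methoxy compound also brings a sharp fall, a number 106 percentage points lower from compound 1 to compound 3 (beyond the scatter), so the two groups together give a much lower number than either gives without the other. Nothing measured here explains this fall. Still open, as far as these compounds go, is whether hydroxy or an amine in place of methoxy would fall as far, and whether bromo in place of chloro would do the same.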